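Aryl groups on the saturated ring carbon: toward compound 4

This account rests on a few compounds, and the source may have more. Where it says the series, first, only, none or still open, it means among the compounds named here.

Measured compounds:
compound 1 `CCCC1C(=O)N(C)c2cnc(Nc3ccc(S(N)(=O)=O)cc3)nc2N1C` — 206 nM
compound 2 `CN1C(=O)C(c2ccc(F)cc2)N(C)c2nc(Nc3ccc(S(N)(=O)=O)cc3)ncc21` — 1770 nM
compound 3 `COc1cccc(C2C(=O)N(C)c3cnc(Nc4ccc(S(N)(=O)=O)cc4)nc3N2C)c1` — 954 nM

In an assay on Sf9 cells for inhibition of serine/threonine-protein kinase 4 (Homo sapiens), read by luminescence and ADP-Glo, with a stated time of 1 h, in the presence of a further agent that is not named here (a lower number here means a stronger inhibitor, a higher number a weaker inhibitor), compound 3 holds the second highest of the three numbers; the nearest is compound 2 (a 1.9-fold lower number from compound 2 to compound 3 (0.27 log units; within the scatter)), the furthest is compound 1 (a 4.6-fold higher number from compound 1 to compound 3 (0.67 log units; beyond the scatter)). Compound 4 `CN1C(=O)C(c2ccccc2Br)N(C)c2nc(Nc3ccc(S(N)(=O)=O)cc3)ncc21` differs from compound 3 by 2-bromophenyl in place of 3-methoxyphenyl on a saturated ring carbon. Among the measured compounds shown here, the steps that bear on this are an 8.6-fold higher number from compound 1 to compound 2 (0.93 log units; beyond the scatter) and a 4.6-fold higher number from compound 1 to compound 3 (0.67 log units; beyond the scatter), which show both aryl groups giving higher numbers than propyl, while a 1.9-fold lower number from compound 2 to compound 3 (0.27 log units; within the scatter) shows the two aryl groups within scatter of each other. For the measured compounds named here, no measured step covers a bromine-bearing aryl group, so the exchange is expected to give a 1.5-fold higher number from compound 3 to compound 4 (0.17 log units; within the scatter), within scatter. For compound 4 the estimate is 1400 nM, range 450 nM to 4500 nM.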

Compound 4, half-maximal inhibitory concentration: 57 nM
Compound 4: the middle estimate sits 25-fold (1.39 log units) above what was measured, outside the stated range (below it).
By their numbers in this assay, from the lowest: compound 4; then compound 1; then compounds 3 and 2 (each within the scatter of the next).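

In this assay, an aryl group on this saturated ring carbon need not give a higher number than propyl: 2-bromophenyl gives a 3.6-fold lower number from compound 1 to compound 4 (0.56 log units; beyond the scatter). The choice of aryl group matters far more than the two earlier aryl groups indicated, with a 17-fold lower number from compound 3 to compound 4 (1.22 log units; beyond the scatter) and a 31-fold lower number from compound 2 to compound 4 (1.49 log units; beyond the scatter). Nothing available explains this difference.

Going by these compounds, whether the lower number follows the bromine itself or its place on the aryl ring remains open, and 2-chlorophenyl or plain phenyl would help to separate the two.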